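A few compounds are considered here, and "the series" means these few. Any claim that something is new, unique, unknown or untested is made for them only; others in the source may bear on it.

Working notes on the series. Within the data shown here, compound 1 `O=C(/C=C/c1ccccc1)NS(=O)(=O)c1ccccc1` gives 3.5 ug/mL in a functional assay on B16-F10 cells (Mus musculus) for antiproliferative activity, read by ELISA and MTT assay, with a stated time of 48 h (on this read-out lower numbers stand for stronger inhibition and higher numbers for weaker inhibition), the lowest of the two numbers so far; the nearest is compound 2 `Cc1ccc(S(=O)(=O)NC(=O)/C=C/c2ccccc2)cc1`, which in this assay gives 13.8 ug/mL. Among the measured compounds shown here, the single measured step in the set, a 3.9-fold higher number from compound 1 to compound 2 (0.60 log units; beyond the scatter), is a modest loss beyond the scatter.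

Compound 3 `O=C(/C=C/c1ccc(F)cc1)NS(=O)(=O)c1ccccc1` is to be measured next. It differs from compound 1 by fluoro in place of hydrogen on an aromatic carbon. For the measured compounds named here, the one step on hand concerns a different group entering at a different aromatic carbon of the shared core, so it bears on this change only loosely; it suggests that a small aromatic substituent can cost some activity, but no step with fluoro exists in the set. The expectation is therefore a step within the scatter, or at most a small loss, a 1.3-fold higher number from compound 1 to compound 3 (0.11 log units; within the scatter). Compound 3 is estimated at 4.5 ug/mL in this assay, with a range of 2 ug/mL to 12 ug/mL.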

Compound 3, half-maximal inhibitory concentration: 2.1 ug/mL
Compound 3: the middle estimate sits 2.1-fold (0.33 log units) above what was measured; the measured number falls inside the stated range.
By their numbers in this assay, from the lowest: compounds 3 and 1 (each within the scatter of the next); then compound 2.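

In this assay, the change from phenyl to 4-fluorophenyl gives a 1.7-fold lower number from compound 1 to compound 3 (0.22 log units; within the scatter), so a fluoro is tolerated on this aromatic carbon, para to a large group, with no change beyond the scatter. This differs from the methyl step, a 3.9-fold higher number from compound 1 to compound 2 (0.60 log units; beyond the scatter), but that step lies at a different aromatic carbon of the shared core and involves a different group, so the two steps do not separate the effect of the group from that of its place. No measurement on hand explains the result of the fluoro change.

On these data alone, whether a larger group at this carbon, such as chloro, methoxy or a carboxylic acid, would keep the value remains open. Also open, as far as these compounds go, is whether fluoro at the carbon that carries methyl in compound 2 would avoid the loss seen there.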